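Ring-nitrogen substituent in a hydroxamate series: amide restored

This account rests on a few compounds, and the source may have more. Where it says the series, first, only, none or still open, it means among the compounds named here.

Two compounds of this series are measured. Compound 1 `COc1ccc(NC(=O)[C@@H]2Cc3ccc(OCC(=O)NO)cc3CN2C(=O)CCCc2ccccc2)cc1` carries a (3-phenylpropyl)carbonyl group on the ring amine nitrogen of the shared core; in an assay on isolated protein for inhibition of histone deacetylase 8 (Homo sapiens), read by fluorescence, with a stated time of 30 min (on this read-out lower numbers stand for stronger inhibition and higher numbers for weaker inhibition), compound 1 gives 114 nM. Compound 2 `COc1ccc(NC(=O)[C@@H]2Cc3ccc(OCC(=O)NO)cc3CN2CCCc2ccccc2)cc1` carries 3-phenylpropyl on the same nitrogen, and in this assay compound 2 gives 1720 nM. Among the compounds with values here, compound 2 thus stands at the highest of the two numbers; the single step of a 15-fold higher number from compound 1 to compound 2 (1.18 log units; beyond the scatter) is large and runs beyond the scatter.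

Compound 3 `COc1ccc(NC(=O)[C@@H]2Cc3ccc(OCC(=O)NO)cc3CN2C(=O)[C@@H]2CCCN2)cc1` is not yet measured. It differs from compound 2 in one place: (pyrrolidin-2-yl)carbonyl in place of 3-phenylpropyl on an amine nitrogen in a ring. The entering group is again carbonyl-linked to the ring nitrogen, as in compound 1, while the six-membered aromatic ring of carbon only is gone and a five-membered non-aromatic ring with 1 hetero atom enters.

Within the data shown here, only the step from compound 1 to compound 2 bears on this change, and it reflects the loss of the carbonyl. Going back to a carbonyl-linked group is therefore expected to lower the number in this assay, though the different ring leaves the size uncertain. The expected step is a 4.9-fold lower number from compound 2 to compound 3 (0.69 log units; beyond the scatter). Compound 3 is estimated at 350 nM, with a range from 80 nM to 1500 nM.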

Compound 3, half-maximal inhibitory concentration: 481 nM
Estimate against measurement, compound 3: 1.4-fold (0.14 log units) below; the range from low to high includes it.
By their numbers in this assay, from the lowest: compound 1; then compound 3; then compound 2.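

Notes on the ring-nitrogen substituent: in this assay, a carbonyl-linked group without any six-membered aromatic ring of carbon only still gives a 3.6-fold lower number from compound 2 to compound 3 (0.55 log units; beyond the scatter), so that ring is not needed for a number below that of the 3-phenylpropyl amine. With the carbonyl held in place, the group on the carbonyl carbon also counts, since pyrrolidin-2-yl in place of 3-phenylpropyl gives a 4.2-fold higher number from compound 1 to compound 3 (0.63 log units; beyond the scatter); both carbonyl-linked compounds therefore lie below compound 2, although they are not equivalent to each other. No supporting evidence bears on why these numbers move, and the step from compound 2 cannot be divided between the carbonyl and the change of ring.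

The compounds shown leave open whether the ring amine of pyrrolidin-2-yl contributes to the number, which cyclopentyl on the same carbonyl carbon would address, and whether the defined stereocentre of that group matters. Also open, on these data alone, is how a shorter acyl group such as acetyl, or a longer chain such as 4-phenylbutanoyl, would stand against compound 1 on the same ring nitrogen.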